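Adding a chloro group to the most active compound

The compounds below may be only part of what the source reports. "The series", "measured", "known", "first", "only" and "open" are said of these compounds alone.

Compound 1, `COc1cc2cc(Oc3ccc(NC(=O)Nc4ccccc4)cc3)c(C)nc2cc1OC`, in a functional assay on T47D cells (Homo sapiens) for inhibition, read by sulforhodamine B assay, with a stated time of 48 h, tested at 10 uM (a lower number here means a stronger effect, a higher number a weaker effect of the compound at the concentration tested), gives 97.1%.
Compound 2, `COc1cc2cc(Oc3ccc(NC(=O)Nc4ccc(C)cc4)cc3)c(C)nc2cc1OC`, in this assay gives 101%.
Compound 3, `COc1cc2cc(Oc3ccc(NC(=O)Nc4cccc(C(F)(F)F)c4)cc3)c(C)nc2cc1OC`, in this assay gives 27.8%.

Compound 3 stands lowest of the three, which in this assay means the strongest effect; the others sit far above it, both beyond the scatter. All three share the same core and differ only in the group on the outer ring attached to the amide-type nitrogen. The step of a number 3.9 percentage points higher from compound 1 to compound 2 (within the scatter) shows that a methyl there changes nothing, while a number 69.3 percentage points lower from compound 1 to compound 3 (beyond the scatter) and a number 73.2 percentage points lower from compound 2 to compound 3 (beyond the scatter) show that a trifluoromethyl there brings a large gain.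

Compound 4, `COc1cc2cc(Oc3ccc(NC(=O)Nc4ccc(Cl)c(C(F)(F)F)c4)cc3)c(C)nc2cc1OC`, is not yet measured. Its change from compound 3 is chloro in place of hydrogen on an aromatic carbon. Among the measured compounds shown here, no measured step tests a chloro, so the only guide is that compound 3 already lies low. Compound 4 is expected to stay low, with the step of a number 7.8 percentage points lower from compound 3 to compound 4 (within the scatter) lying within the scatter or somewhat lower because a number 73.2 percentage points lower from compound 2 to compound 3 (beyond the scatter) shows this outer ring tolerates a halogen-rich group well. The estimate for compound 4 in this assay is 20%, with a range from 5% to 45%.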

Compound 4, a percentage reported as activity, at one concentration (the size of the read-out at that concentration, not a potency): 21.4%
For compound 4 the middle estimate is 1.4 percentage points below the measured one; low and high end bracket the measured number.
By their numbers in this assay, from the lowest: compounds 4 and 3 (each within the scatter of the next); then compounds 1 and 2 (each within the scatter of the next).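

In this assay the chloro, placed ortho to the trifluoromethyl group and para to a large group, brings a number 6.4 percentage points lower from compound 3 to compound 4 (within the scatter) and so leaves compound 3 and compound 4 indistinguishable. The earlier compounds shown here did not show that this ring can take a second group on top of the trifluoromethyl and still hold the large gain, seen in a number 75.7 percentage points lower from compound 1 to compound 4 (beyond the scatter) and in a number 79.6 percentage points lower from compound 2 to compound 4 (beyond the scatter) on the same outer ring. No measurement here gives a reason for this tolerance.

The compounds shown leave open whether a chloro on the plain phenyl ring of compound 1 would do anything without the trifluoromethyl group. They also leave open how a methoxy, an amine or a carboxylic acid in the chloro's place would read in this assay on this ring.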